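A few compounds are considered here, and "the series" means these few. Any claim that something is new, unique, unknown or untested is made for them only; others in the source may bear on it.

Measured so far:
- compound 1, `O=C(N/N=C/c1ccc(F)cc1)c1cccnc1Nc1cccc(C(F)(F)F)c1`: 36.5%
- compound 2, `O=C(N/N=C/c1cccc(Cl)c1)c1cccnc1Nc1cccc(C(F)(F)F)c1`: 40.4%
- compound 3, `O=C(N/N=C/c1ccc(O)cc1)c1cccnc1Nc1cccc(C(F)(F)F)c1`: 61.6%

All three were tested in a functional assay on the whole organism (strain Wistar) for inhibition, with Rattus norvegicus as the target, read by paw edema, with a stated time of 4 h, at a dose of 10 mg/kg by the intraperitoneal route; on this read-out lower numbers stand for less inhibition and higher numbers for more inhibition at the one dose given (going by the name of the read-out). Compound 3 stands highest of the three: its gap to the nearest, compound 2, is a number 21.2 percentage points higher from compound 2 to compound 3 (beyond the scatter), and to the furthest, compound 1, a number 25.1 percentage points higher from compound 1 to compound 3 (beyond the scatter), both beyond the scatter. Compounds 1 and 2 differ from each other by a number 3.9 percentage points higher from compound 1 to compound 2 (within the scatter), which is within the scatter.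

Compound 4, `COc1ccc(/C=N/NC(=O)c2cccnc2Nc2cccc(C(F)(F)F)c2)cc1`, is not yet measured. It differs from compound 3 in one place: methyl in place of hydrogen on an oxygen on an aromatic ring. Within the data shown here, no measured step changes this same oxygen, so none of the three steps bears on it directly. The two steps that do involve compound 3 show that the hydroxy compound sits above both halogen compounds, and compound 4 keeps the oxygen while losing its hydrogen. The expected outcome is a step of a number 14.6 percentage points lower from compound 3 to compound 4 (beyond the scatter), with compound 4 expected to land between the halogen compounds and compound 3. Compound 4 is estimated at 47%, within 32% to 62%.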

Compound 4, a percentage reported as inhibition, in the whole organism at one dose (the size of the read-out at that dose, not a potency): 14%
The estimate for compound 4 lay 33 percentage points above the measured number; measured number outside the range, below it.
By their numbers in this assay, from the lowest: compound 4; then compounds 1 and 2 (each within the scatter of the next); then compound 3.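

In this assay, putting methyl on the oxygen of the 4-hydroxyphenyl group gives a large change, a number 47.6 percentage points lower from compound 3 to compound 4 (beyond the scatter), so in this series the hydrogen on that oxygen counts for far more than the oxygen's presence alone. The 4-methoxyphenyl group also falls short of both halogen-bearing groups, with a number 26.4 percentage points lower from compound 2 to compound 4 (beyond the scatter) and with a number 22.5 percentage points lower from compound 1 to compound 4 (beyond the scatter), which means that capping the hydroxy group takes this compound beyond the halogen compounds rather than to a point short of them. No measurement here explains why the methyl has this effect.

Still open, from the compounds shown here alone, is how an amine or a carboxylic acid in place of the hydroxy group would read at this same place. Also open, going by these compounds, is whether a longer chain on the oxygen, such as ethyl, would give a number like that of the methyl.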